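Swapping Bromo for Cyano: Expected Plasma Half-Life

The source may report more compounds than this note shows. Statements on the series, on what has been measured and on what is new or still open speak of the compounds shown alone.

Compound 1 `CN(/N=N/c1ccc(Br)cc1)C(=O)CCCCc1ccc(O)cc1` is the longer-lived of the two compounds measured in an ADME assay on a cell-free system (plasma, Homo sapiens) for metabolic stability, read by HPLC; on this read-out lower numbers stand for a shorter-lived compound and higher numbers for a longer-lived compound: compound 1 gives 162 h, whereas compound 2 `CN(/N=N/c1ccc(C#N)cc1)C(=O)CCc1cccc(O)c1` gives 2.7 h, a gap well beyond the usual scatter. Compound 2 differs from compound 1 in more than one place, so no single change can be read from that gap.

Compound 3 `CN(/N=N/c1ccc(C#N)cc1)C(=O)CCCCc1ccc(O)cc1` is compound 1 with one alteration: cyano in place of bromo on an aromatic carbon. Put another way, 4-bromophenyl becomes 4-cyanophenyl, while the rest of the molecule is unchanged.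

Among the compounds with values here, no measured pair shows this change on its own. Compound 2, which also carries cyano, sits far lower than compound 1, so a decrease is expected, though its size is uncertain; the expected step from compound 1 to compound 3 is a 5.4-fold lower number from compound 1 to compound 3 (0.73 log units; beyond the scatter). Compound 3 is therefore estimated at 30 h, within a range of 5 h to 160 h.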

Compound 3, half-life: 11.8 h
The estimate for compound 3 lay 2.5-fold (0.41 log units) above the measured number, within the range that was stated.
By their numbers in this assay, from the lowest: compound 2; then compound 3; then compound 1.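

Read on its own in this assay, cyano in place of bromo on the aromatic carbon gives a 14-fold lower number from compound 1 to compound 3 (1.14 log units; beyond the scatter), so this single position can by itself shift plasma half-life by a large amount. The earlier gap between compound 1 and compound 2 could not show this, as those two compounds differ in more than one place; this pair isolates one change, with the rest of the molecule held constant. Nothing available accounts for the size of this step.

As far as these compounds go, whether the same swap would give a similar step on the chain and phenol arrangement of compound 2 remains open. Also open, from the compounds shown here alone, is how other groups in this place, such as a fluoro, a methoxy or an amine, would compare with bromo and cyano.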